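Diethylamino for dimethylamino on the propyl amide chain

This account rests on a few compounds, and the source may have more. Where it says the series, first, only, none or still open, it means among the compounds named here.

Of the compounds shown here, three with a shared core have been measured in an assay on isolated protein for binding affinity to vitamin D3 receptor (Homo sapiens), with a stated time of 4 h; a higher number here means a weaker inhibitor, a lower number a stronger inhibitor. Compound 1 `CCN(CC)CCCNC(=O)c1ccc(C(CC)(CC)c2ccc(OCC(=O)C(C)(C)C)c(C)c2)n1CC` gives 863 nM, and compound 2 `CCn1c(C(=O)NCCN)ccc1C(CC)(CC)c1ccc(OCC(=O)C(C)(C)C)c(C)c1` gives 1010 nM; the change a 1.2-fold higher number from compound 1 to compound 2 (0.07 log units; within the scatter). Compound 3 `CCn1c(C(=O)NCCCN(C)C)ccc1C(CC)(CC)c1ccc(OCC(O)C(C)(C)C)c(C)c1` gives 197 nM, the lowest of the three numbers, with compound 1 the nearest and compound 2 the furthest, both beyond the scatter.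

Compound 4 `CCN(CC)CCCNC(=O)c1ccc(C(CC)(CC)c2ccc(OCC(O)C(C)(C)C)c(C)c2)n1CC` differs from compound 3 in one place: diethylamino in place of dimethylamino on a saturated chain carbon, three bonds along the chain from an amide-type nitrogen. Going by the values given here, no measured step covers this exact exchange. Among the compounds with values here, the only step at the amine end of the chain, from compound 1 to compound 2, stayed within the scatter despite removing two ethyl groups and a chain carbon, so an exchange of methyl for ethyl on the same amine is expected to move the number little, if at all. Compound 3 also carries the alcohol that compound 4 keeps, which separates it from compounds 1 and 2.

Compound 4 is therefore expected to give 230 nM, within 100 nM to 550 nM, a step of a 1.2-fold higher number from compound 3 to compound 4 (0.07 log units; within the scatter) that is expected to stay inside the scatter.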

Compound 4, half-maximal inhibitory concentration: 71.1 nM
Compound 4: the middle estimate sits 3.2-fold (0.51 log units) above what was measured; the measured number lies below the stated range.
By their numbers in this assay, from the lowest: compound 4; then compound 3; then compounds 1 and 2 (each within the scatter of the next).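

In this assay, going by these compounds alone, the amine end of the chain turns out to respond to a small exchange: diethylamino in place of dimethylamino, on a saturated chain carbon, three bonds along the chain from an amide-type nitrogen, gives a 2.8-fold lower number from compound 3 to compound 4 (0.44 log units; beyond the scatter), while the only earlier step at this end was a 1.2-fold higher number from compound 1 to compound 2 (0.07 log units; within the scatter). Within the data shown here, compound 4 also gives a first direct reading at the other end of the molecule, where 1-hydroxy-2,2-dimethylpropyl in place of (tert-butyl)carbonyl, on a saturated chain carbon bound to an oxygen on an aromatic ring, gives a 12-fold lower number from compound 1 to compound 4 (1.08 log units; beyond the scatter). Nothing available here explains either step.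

As far as these compounds go, it remains open whether the exchange of dimethylamino for diethylamino has the same size in compounds carrying (tert-butyl)carbonyl. Also open, from the compounds shown here alone, is how a piperidine on the propyl chain, or a methyl ether in place of the alcohol, would read.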